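Regioisomeric oxadiazole swap on the anilinomethyl-imidazoline series

A few compounds are considered here, and "the series" means these few. Any claim that something is new, unique, unknown or untested is made for them only; others in the source may bear on it.

Measured so far, in a functional assay for activation of Alpha-1A adrenergic receptor (Homo sapiens), read by calcium flux; a lower number here means that less compound is needed, a higher number that more compound is needed for the effect:
compound 1, `c1csc(-c2ccccc2NCC2=NCCN2)c1`, 2.24 nM
compound 2, `c1ccc(-c2cnoc2)c(NCC2=NCCN2)c1`, 45.7 nM
compound 3, `Cc1noc(-c2ccccc2NCC2=NCCN2)n1`, 661 nM

Compound 3 stands at the highest number of the three. The step of a 14-fold higher number from compound 2 to compound 3 (1.16 log units; beyond the scatter) and the step of a 300-fold higher number from compound 1 to compound 3 (2.47 log units; beyond the scatter) both place it well beyond the scatter from the other two, so within this small set it needs clearly the most compound.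

Compound 4, `Cc1nc(-c2ccccc2NCC2=NCCN2)no1`, differs from compound 3 only in the five-membered ring: 5-methyl-1,2,4-oxadiazol-3-yl in place of 3-methyl-1,2,4-oxadiazol-5-yl on an aromatic carbon. The ring keeps the same atoms, joined differently, so the change is smaller in kind than either of the measured swaps, which exchanged one heteroaromatic ring for another of different composition (a 20-fold higher number from compound 1 to compound 2 (1.31 log units; beyond the scatter), a 14-fold higher number from compound 2 to compound 3 (1.16 log units; beyond the scatter)). For the measured compounds named here, those steps show that this assay responds strongly to what sits on that aromatic carbon, but none of them swaps the attachment point of one and the same ring, so no direct precedent exists for the size or direction of the present step.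

Given that the ring composition is unchanged, the expectation for compound 4 is a number close to compound 3, with a wide band: an estimated 1.5-fold lower number from compound 3 to compound 4 (0.17 log units; within the scatter), giving an expected 450 nM, between 100 nM and 2000 nM.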

Compound 4, half-maximal effective concentration: 724 nM
Compound 4: the middle estimate sits 1.6-fold (0.21 log units) below what was measured; the range from low to high includes it.
By their numbers in this assay, from the lowest: compound 1; then compound 2; then compounds 3 and 4 (each within the scatter of the next).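

In this assay, for the compounds shown here, moving the attachment point of one and the same ring can now be read directly: with a 1.1-fold higher number from compound 3 to compound 4 (0.04 log units; within the scatter), 5-methyl-1,2,4-oxadiazol-3-yl and 3-methyl-1,2,4-oxadiazol-5-yl cannot be told apart on this aromatic carbon, whereas the earlier steps showed only that exchanging one ring for another of different composition moves the number. The gaps to the other two rings hold for the second methyl oxadiazole as well (with a 16-fold higher number from compound 2 to compound 4 (1.20 log units; beyond the scatter) and a 320-fold higher number from compound 1 to compound 4 (2.51 log units; beyond the scatter)), so the distance from 1,2-oxazol-4-yl and thiophen-2-yl does not belong to one oxadiazole isomer alone. Nothing available explains why the two isomers read alike.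

Going by these compounds, whether the methyl contributes to the number stays open, and an unsubstituted oxadiazole, or an aminomethyl or carboxylic acid in place of the methyl, would address that. On these data alone, it is also open whether the same indifference to the joining of the ring holds for other rings at this position, for example thiophen-3-yl against thiophen-2-yl.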